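Working notes: from compound 3 to compound 4

The source may hold more compounds than are shown below. What is called first, only, known or untested is meant among the compounds shown, and "the series" means these compounds.

Measured so far in a functional assay on Rec1 cells (Homo sapiens) for inhibition, read by luminescence and CellTiter-Glo, with a stated time of 72 h (on this read-out lower numbers stand for stronger inhibition and higher numbers for weaker inhibition), are three compounds.
- compound 1 `CCOC(=O)c1cc(-c2ccc(Oc3ccccc3)cc2)nn1Cc1cccc(NC(=O)CCl)c1` gives 400 nM
- compound 2 `C/C=C/C(=O)Nc1ccc(Cn2nc(-c3ccc(Oc4ccccc4)cc3)cc2C(=O)OCC)cc1` gives 13100 nM
- compound 3 `C=CC(=O)Nc1cccc(Cn2nc(-c3ccc(Oc4ccccc4)cc3)cc2C(=O)OCC)c1` gives 3300 nM

Compound 3 holds the second highest of these numbers, nearer compound 2 than compound 1. Compound 4 `C=CC(=O)Nc1cccc(Cn2nc(-c3ccc(Oc4ccccc4)cc3)cc2C(=O)O)c1` differs from compound 3 by hydrogen in place of ethyl on an oxygen next to a carbonyl group and so reads ethoxycarbonyl to carboxy. Within the data shown here, no measured step touches this oxygen. The steps of a 33-fold higher number from compound 1 to compound 2 (1.52 log units; beyond the scatter) and an 8.3-fold higher number from compound 1 to compound 3 (0.92 log units; beyond the scatter) and a 4.0-fold lower number from compound 2 to compound 3 (0.60 log units; beyond the scatter) all lie elsewhere, so they offer a scale of size but no direction. Among the measured compounds shown here, on that scale, a modest rise is expected in this assay as a judgement, since no pair tests this change. The expected change is a 3.0-fold higher number from compound 3 to compound 4 (0.48 log units; beyond the scatter) in this estimate. For compound 4 the estimated value is 10000 nM within an expected range of 2500 nM to 40000 nM here.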

Compound 4, half-maximal inhibitory concentration: 33100 nM
Compound 4: middle estimate off by 3.3-fold (0.52 log units), on the low side, within the range that was stated.
By their numbers in this assay, from the lowest: compound 1; then compound 3; then compound 2; then compound 4.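

Hydrogen in place of ethyl on the oxygen next to a carbonyl group is the first change measured at this position: in this assay it gives a 10-fold higher number from compound 3 to compound 4 (1.00 log units; beyond the scatter). The ethoxycarbonyl end of the series therefore moves the number too, not only the groups on the phenyl ring. Nothing available explains this step.

On these data alone, whether a methyl ester, a longer ester chain or a primary amide here would stay near compound 3 remains open. Also open, as far as these compounds go, is whether ethoxycarbonyl to carboxy costs the same with the chloromethyl carbonyl group of compound 1.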